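Two Triazole Amides and a Halogen Swap

The compounds below may be only part of what the source reports. "The series", "measured", "known", "first", "only" and "open" are said of these compounds alone.

Measured compounds:
- compound 1, `CCOC(=O)C1=Cc2ccccc2OC1(OCc1cn(-c2ccc(F)cc2)nn1)C(F)(F)F`: 8400 nM
- compound 2, `CCOC(=O)C1=Cc2ccccc2OC1(OCc1cn(CC(=O)Nc2ccccc2F)nn1)C(F)(F)F`: 49900 nM

Compound 1 and compound 2 share the same core and differ only on the aromatic nitrogen of the triazole. In a functional assay on HeLa cells (Homo sapiens) for inhibition, read by MTT assay, with a stated time of 24 h (a higher number here means a weaker inhibitor, a lower number a stronger inhibitor), compound 1 gives 8400 nM, while compound 2 gives 49900 nM, the higher of the two numbers; the step is a 5.9-fold higher number from compound 1 to compound 2 (0.77 log units; beyond the scatter), so compound 2 is the weaker inhibitor of the pair.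

Compound 3, `CCOC(=O)C1=Cc2ccccc2OC1(OCc1cn(CC(=O)Nc2ccc(I)cc2Cl)nn1)C(F)(F)F`, keeps the amide arm of compound 2 and alters only the ring on its nitrogen: 2-chloro-4-iodophenyl in place of 2-fluorophenyl on an amide-type nitrogen. Going by the values given here, no measured step touches that ring; the one step known, from compound 1 to compound 2, changes the whole arm on the triazole nitrogen and says nothing about swapping one halogenated phenyl for another on the amide nitrogen. With nothing in the data pointing either way, a step no larger than the usual scatter is expected, in no particular direction, giving a 1.1-fold lower number from compound 2 to compound 3 (0.04 log units; within the scatter) as the estimate. For compound 3 in this assay the expected value is 45000 nM, within a range of 12000 nM to 160000 nM.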

Compound 3, half-maximal inhibitory concentration: 26100 nM
Compound 3: middle estimate off by 1.7-fold (0.24 log units), on the high side, and the stated range covers the measured number.
By their numbers in this assay, from the lowest: compound 1; then compounds 3 and 2 (each within the scatter of the next).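

In this assay, putting 2-chloro-4-iodophenyl in place of 2-fluorophenyl on the amide-type nitrogen gives a 1.9-fold lower number from compound 2 to compound 3 (0.28 log units; within the scatter) and so stays within the scatter: compound 2 and compound 3 cannot be told apart, even though the halogens on the ring are entirely different. The comparison with the directly attached ring gives a 3.1-fold higher number from compound 1 to compound 3 (0.49 log units; beyond the scatter) and lies beyond the scatter, as does a 5.9-fold higher number from compound 1 to compound 2 (0.77 log units; beyond the scatter), so both compounds with the longer amide arm read as weaker inhibitors than compound 1, whichever of these two halogenated rings the arm carries. Nothing available here explains these numbers.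

As far as these compounds go, the change from compound 2 to compound 3 replaces fluorine with chlorine and adds iodine in one move, so the part played by each halogen stays open, and a small real effect from each could be hidden within the scatter. Also open, from the compounds shown here alone, is how the reading would respond to an amide ring bearing an amine or a carboxylic acid, or to a longer chain between the triazole and the amide.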